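The source may report more compounds than this note shows. Statements on the series, on what has been measured and on what is new or still open speak of the compounds shown alone.

Measured in a functional assay on HCT-116 cells (Homo sapiens) for inhibition, read by MTT assay, with a stated time of 72 h; a higher number here means a weaker inhibitor, a lower number a stronger inhibitor:

Compound 1 `COc1cc(Oc2cccc(Nc3ccccc3)c2)cc(OC)c1CNCc1ccc(Cl)cc1`: 3310 nM
Compound 2 `COc1cc(Oc2cccc(Nc3ccccc3)c2)cc(OC)c1CNCc1ccc(C)cc1`: 13800 nM
Compound 3 `COc1cc(Oc2cccc(Nc3ccccc3)c2)cc(OC)c1CNCc1ccc(F)cc1`: 4220 nM

These three compounds share one core and differ only in a single group on the outer ring. Compound 3 stands second highest of the three numbers: it sits within the scatter of compound 1, as a 1.3-fold higher number from compound 1 to compound 3 (0.11 log units; within the scatter) shows, and beyond the scatter of compound 2, as a 3.3-fold lower number from compound 2 to compound 3 (0.51 log units; beyond the scatter) shows.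

Compound 4 `COc1ccc(CCCNCc2c(OC)cc(Oc3cccc(Nc4ccccc4)c3)cc2OC)cc1` is the next step from compound 3: 2-(4-methoxyphenyl)ethyl in place of 4-fluorophenyl on a saturated chain carbon bound to an amine nitrogen. Among the measured compounds shown here, the measured steps, a 4.2-fold higher number from compound 1 to compound 2 (0.62 log units; beyond the scatter), a 1.3-fold higher number from compound 1 to compound 3 (0.11 log units; within the scatter) and a 3.3-fold lower number from compound 2 to compound 3 (0.51 log units; beyond the scatter), each swap one small group on that ring and leave the chain untouched, so none of them directly covers a longer chain or a methoxy group; they show only that one change on this ring can shift this assay by a modest amount. The step to compound 4 is therefore expected to be modest as well, with its direction uncertain, estimated as a 1.4-fold higher number from compound 3 to compound 4 (0.15 log units; within the scatter). Compound 4 is expected to give about 6000 nM in this assay, within a range from 2000 nM to 20000 nM.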

Compound 4, half-maximal inhibitory concentration: 2850 nM
Beside the measured number, compound 4's estimate is 2.1-fold (0.32 log units) above it, within the range that was stated.
By their numbers in this assay, from the lowest: compounds 4, 1 and 3 (each within the scatter of the next); then compound 2.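

In this assay, this place on a saturated chain carbon bound to an amine nitrogen accepts a much larger change than a swap of one small group on the ring: going from 4-fluorobenzyl to 3-(4-methoxyphenyl)propyl gives a 1.5-fold lower number from compound 3 to compound 4 (0.17 log units; within the scatter), and the comparison with the chloro member gives a 1.2-fold lower number from compound 1 to compound 4 (0.06 log units; within the scatter), so both steps stay inside the scatter. Only a 4.8-fold lower number from compound 2 to compound 4 (0.69 log units; beyond the scatter) goes beyond the scatter, which leaves the 4-methylphenyl member standing apart from the other three in this small set. Nothing measured here gives a reason for these numbers.

Compound 4 changes the chain and the ring group together, so a 4-methoxybenzyl group or a plain 3-phenylpropyl group would be needed to separate the two changes. Also open, from the compounds shown here alone, is how a still longer chain or a carboxylic acid at this place would read in this assay.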